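Removing One Fluorine: From Compound 2 to Compound 3

This account rests on a few compounds, and the source may have more. Where it says the series, first, only, none or still open, it means among the compounds named here.

Among the measured compounds shown here, compound 2 `Cc1ccc2ncc(S(=O)(=O)c3cc(F)cc(F)c3)c(N3CCC(C)CC3)c2c1` gives the higher of the two numbers so far in an assay on isolated protein for displacement of a labelled ligand from metabotropic glutamate receptor 5 (Homo sapiens), with a stated time of 60 min, tested at 1 uM (on this read-out lower numbers stand for less inhibition and higher numbers for more inhibition at the one concentration tested (going by the name of the read-out)), namely 72%. Its nearest neighbour is compound 1 `COc1ccc(S(=O)(=O)c2cnc3ccc(C)cc3c2N2CCC(C)CC2)cc1`, which in this assay gives 62%; the step of a number 10 percentage points higher from compound 1 to compound 2 (within the scatter) lies within the scatter, so the two compounds cannot be ranked. Compound 3 `Cc1ccc2ncc(S(=O)(=O)c3cccc(F)c3)c(N3CCC(C)CC3)c2c1` differs from compound 2 by hydrogen in place of fluoro on an aromatic carbon.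

For the measured compounds named here, only one measured step bears on this change, and only loosely: the step from compound 1 to compound 2 exchanged the whole aryl group on the sulfonyl sulfur and moved the read-out by a number 10 percentage points higher from compound 1 to compound 2 (within the scatter), a shift within the scatter. Going by the values given here, no measured pair removes a single fluoro. Compound 3 is therefore expected to stay close to compound 2, with an expected step of a number 7 percentage points lower from compound 2 to compound 3 (within the scatter), not beyond the scatter. For compound 3 the estimated value in this assay is 65%, within a range of 45% to 82%.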

Compound 3, a percentage reported as inhibition, at one concentration (the size of the read-out at that concentration, not a potency): 94%
Beside the measured number, compound 3's estimate is 29 percentage points below it, and the stated range ends below it.
By their numbers in this assay, from the lowest: compounds 1 and 2 (each within the scatter of the next); then compound 3.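

In this assay, the exchange of a single fluoro for hydrogen, 3,5-difluorophenyl to 3-fluorophenyl, gives a number 22 percentage points higher from compound 2 to compound 3 (beyond the scatter) and so moves the read-out past the scatter, which the earlier exchange of the whole aryl group did not do. This aromatic carbon, meta to a fluoro group, is therefore a place where one atom changes the result, and on the sulfonyl sulfur 3-fluorophenyl in place of 4-methoxyphenyl gives a number 32 percentage points higher from compound 1 to compound 3 (beyond the scatter) as a clear separation. Nothing measured here accounts for the higher number with hydrogen.

Open, as far as these compounds go, is how a plain phenyl on the sulfonyl sulfur would read, which would test the remaining fluoro. Also open, from the compounds shown here alone, is whether a chloro or a nitrile at the vacated carbon would read like hydrogen or like fluoro.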